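The source may hold more compounds than are shown below. What is called first, only, known or untested is meant among the compounds shown, and "the series" means these compounds.

Compound 1 `Cc1ccccc1NNC(=O)c1cccc(NS(=O)(=O)c2cnc(O)nc2O)c1` — > 20000 nM
Compound 2 `O=C(NNC(=O)c1ccc(NS(=O)(=O)c2cnc(O)nc2O)cc1)c1ccc(F)cc1` — > 20000 nM

All measurements here come from a functional assay on MDA-MB-231 cells (Homo sapiens) for antiproliferative activity, read by MTT assay, with a stated time of 24 h; on this read-out lower numbers stand for stronger inhibition and higher numbers for weaker inhibition. In this assay compound 1 gives > 20000 nM, which is a limit of the assay and not a number. In this assay compound 2 gives > 20000 nM, again a limit. Both values thus sit at the limit of > 20000 nM in this assay, at which 2 of the 2 values shown sit, so compound 1 cannot be placed above or below compound 2 on the numbers shown: all that is known of either is that no half-maximal inhibitory concentration was reached within the tested range.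

The step followed here leads from compound 1 to compound 3 `O=C(NNC(=O)c1ccccc1Cl)c1cccc(NS(=O)(=O)c2cnc(O)nc2O)c1`, which has not yet been measured. The change is (2-chlorophenyl)carbonyl in place of 2-methylphenyl on an amine nitrogen. Compound 2 carries a carbonyl-linked hydrazide of a related kind on the same core and, as noted, gives only a limit. Within the data shown here, no measured pair differs in a single place, so no size of step can be read directly from the data. In this assay the step of a number no higher from compound 1 to compound 3 (the limit leaves the size open) is expected to be none beyond the scatter. This expectation rests on compound 2, which in this assay gives > 20000 nM, a limit that sits at the limit of > 20000 nM in this assay, at which 2 of the 2 values shown sit. Compound 3 is therefore expected at about 20000 nM, with a range from 8000 nM to 60000 nM.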

Compound 3, half-maximal inhibitory concentration: 2360 nM
The estimate for compound 3 lay 8.5-fold (0.93 log units) above the measured number; the whole stated range lies above it.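

In this assay the change on the amine nitrogen gives an at least 8.4-fold lower number from compound 1 to compound 3 (0.92 log units; beyond the scatter), the first sign that this position can move the read-out at all. The earlier compounds shown here could not show this, since neither gave a number, whereas compound 3 shows that a (2-chlorophenyl)carbonyl group here can bring a compound of this kind within the measurable range. Compound 3 is thus the only one of the three with a true number, while the other two values remain limits of the assay and no cause for the gain can be assigned: the limit of > 20000 nM in this assay, at which 2 of the 3 values shown sit.

The change brings in a carbonyl and swaps methyl for chlorine in a single step, so the compounds shown cannot tell which of these matters, and the full size of the step stays open; no step to compound 2 can be read, as it differs from the others in more than one place. As far as these compounds go, it also remains open whether a (2-methylphenyl)carbonyl group, an unsubstituted phenylcarbonyl group, or a ring carrying an amine or a carboxylic acid in place of the chlorine would give a similar number.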